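The compounds below may be only part of what the source reports. "The series", "measured", "known", "first", "only" and "open" are said of these compounds alone.

Compound 1 `CC(C)CCC(=O)N[C@@H](C(=O)N1CCC(c2ccc(Cl)cc2)CC1)C(C)C` is an amide of an isopentylcarbonyl group on a valine-type core, and in an assay on THP-1 cells for displacement of a labelled ligand from C-C chemokine receptor type 1 (Homo sapiens) (on this read-out higher numbers stand for weaker inhibition and lower numbers for stronger inhibition), compound 1 gives 26 nM. Among the three measured compounds its number is the lowest, yet the gap to compound 3 `CC[C@@H](C)[C@@H](NC(=O)c1ccccc1)C(=O)N1CCC(c2ccc(Cl)cc2)CC1`, which in this assay gives 45 nM, stays within the scatter, while the gap to compound 2 `CC[C@@H](NC(=O)c1ccccc1)C(=O)N1CCC(c2ccc(Cl)cc2)CC1`, which in this assay gives 121 nM, lies beyond it. Compounds 2 and 3 both carry a benzoyl group on the amide nitrogen and differ from each other only in the side chain, where a 2.7-fold lower number from compound 2 to compound 3 (0.43 log units; beyond the scatter).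

Compound 4 `CC(C)[C@@H](NC(=O)c1ccc(F)cc1)C(=O)N1CCC(c2ccc(Cl)cc2)CC1` keeps the side chain of compound 1 and changes the acyl group: 4-fluorophenyl in place of isopentyl on a carbonyl carbon. Going by the values given here, no measured pair isolates this exchange, and no measured compound carries the fluorine. What the data do show is that compound 3, with an aromatic acyl group and a branched side chain, gives a number within the scatter of compound 1. On that basis the step from compound 1 to compound 4 in this assay is expected to be small, a 1.5-fold higher number from compound 1 to compound 4 (0.19 log units; within the scatter), with no clear direction. Compound 4 is therefore estimated to give 40 nM in this assay, within a range from 15 nM to 110 nM.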

Compound 4, half-maximal inhibitory concentration: 118 nM
For compound 4 the middle estimate is 3.0-fold (0.47 log units) below the measured one; the measured number lies above the stated range.
By their numbers in this assay, from the lowest: compounds 1 and 3 (each within the scatter of the next); then compounds 4 and 2 (each within the scatter of the next).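

With the side chain and the rest of the core held fixed, this position now has its first direct reading: 4-fluorophenyl in place of isopentyl on a carbonyl carbon gives a 4.5-fold higher number from compound 1 to compound 4 (0.66 log units; beyond the scatter) in this assay. The earlier compounds held no pair that changed the acyl group alone, so the only listed step among them concerned the side chain. This result shows that the acyl position also moves the number, and that on this side chain the exchange of an open chain for a fluorinated aromatic ring goes toward weaker inhibition. No measurement at hand says why the number moves with this exchange.

The exchange replaces a chain with a ring and also brings in a fluorine, and the compounds shown leave open which of these carries the step, a question that an unsubstituted phenyl or a 4-chlorophenyl on the same carbonyl carbon would bear on. Also open, on these data alone, is how a saturated ring such as cyclohexyl, a shorter chain such as ethyl, or a chain ending in an amine would read at this place.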